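Trading an Acetoxy Group for Ethoxy

A few compounds are considered here, and "the series" means these few. Any claim that something is new, unique, unknown or untested is made for them only; others in the source may bear on it.

In a functional assay on DA-3 cells for cytotoxicity against DA-3 cell line (Mus musculus), read by MTT assay (on this read-out lower numbers stand for stronger inhibition and higher numbers for weaker inhibition), compound 1 `CC(=O)O[C@@H]1OC(=O)[C@@](C)(C(C)=O)[C@@H]1C` gives 9000 nM. Compound 3 `CC(=O)[C@]1(C)C(=O)O[C@@H](OC(=O)c2ccccc2)[C@H]1C` gives 2000 nM, which leaves compound 1 with the higher of the two exact numbers. Compound 2 `CC(=O)O[C@@H]1OC(=O)[C@@](OC(C)=O)(C(C)=O)[C@@H]1C` reaches only a limit of the assay, > 50000 nM.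

Compound 4 `CCO[C@@H]1OC(=O)[C@@](C)(C(C)=O)[C@@H]1C` has not yet been measured. It differs from compound 1 by ethyl in place of acetyl on an oxygen on a saturated carbon, so acetoxy becomes ethoxy. The most relevant measured change alters that same acetyl group, where phenyl in place of methyl gave a 4.5-fold lower number from compound 1 to compound 3 (0.65 log units; beyond the scatter). The other, acetoxy in place of methyl on a saturated ring carbon, lies elsewhere and gave an at least 5.5-fold higher number from compound 1 to compound 2 (0.74 log units; beyond the scatter), so it offers only a rough sense of scale. Both steps are modest or larger, which suggests that a change of similar size is plausible here. Compound 4 loses the carbonyl that compound 3 retains at 2000 nM, so a modest move towards a higher number is expected, with real uncertainty. The expected change is a 2.2-fold higher number from compound 1 to compound 4 (0.35 log units; beyond the scatter). Compound 4 is estimated at 20000 nM, with an expected range of 6000 nM to 60000 nM.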

Compound 4, half-maximal inhibitory concentration: > 50000 nM
Compound 4: a limit, no number; the forecaster's own chance of this, stated with the estimate: 30%; middle value at least 2.5-fold (0.39 log units) from the limit.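

Replacing acetyl with ethyl on this oxygen gives an at least 5.5-fold higher number from compound 1 to compound 4 (0.74 log units; beyond the scatter) in this assay. Until now, the only change shown at this acetyl group was phenyl in place of methyl, which kept the carbonyl and gave a 4.5-fold lower number from compound 1 to compound 3 (0.65 log units; beyond the scatter), whereas this step removes the carbonyl and shows that the position is sensitive in the opposite direction as well. The value of compound 4, > 50000 nM, is a limit of the assay and not a number, so the step has a lower bound but no known full size: the limit of > 50000 nM in this assay, at which 2 of the 4 values shown sit.

Within the data shown here, with only one group lacking a carbonyl at this oxygen, the loss cannot yet be tied to the carbonyl rather than to ethyl itself. A free hydroxyl, a benzyl ether or a longer acyl chain such as butanoyl could help separate the two.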